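The source may hold more compounds than are shown below. What is called first, only, known or untested is meant among the compounds shown, and "the series" means these compounds.

Measured so far:
Compound 1, `CCS(=O)(=O)Nc1cc(-c2ccc3ncnc(Nc4ccc(F)cc4)c3c2)cnc1OC`: 2400 nM
Compound 2, `CCS(=O)(=O)Nc1cc(-c2ccc3ncnc(Nc4ccc(OC(F)(F)F)cc4)c3c2)cnc1OC`: 22400 nM

In a functional assay on SNU-638 cells (Homo sapiens) for cytotoxicity, read by sulforhodamine B assay, with a stated time of 72 h (on this read-out lower numbers stand for stronger inhibition and higher numbers for weaker inhibition), compound 2 gives the highest of the two numbers; its nearest neighbour is compound 1, which sits a 9.3-fold higher number from compound 1 to compound 2 (0.97 log units; beyond the scatter) step below it in the other direction, so compound 2 is the weaker of the two by a margin beyond the scatter.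

Compound 3, `CCS(=O)(=O)Nc1cc(-c2ccc3ncnc(Nc4ccc(OC)cc4)c3c2)cnc1OC`, has not been measured. It differs from compound 2 by methyl in place of trifluoromethyl on an oxygen on an aromatic ring. Among the compounds with values here, no measured pair carries exactly this change. Within the data shown here, the one measured step, a 9.3-fold higher number from compound 1 to compound 2 (0.97 log units; beyond the scatter), shows that a fluoro on that aromatic carbon gave a much lower number than trifluoromethoxy. Methoxy is neither of these, so the only bearing of that step is indirect: it shows that what sits on this phenyl ring can move the result by well beyond the scatter, and it gives no sign of which way methoxy falls.

The expectation for compound 3 in this assay is therefore a moderate step toward the lower number of compound 1, a 3.7-fold lower number from compound 2 to compound 3 (0.57 log units; beyond the scatter), with a wide range. Compound 3 is estimated at 6000 nM, between 1500 nM and 25000 nM.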

Compound 3, half-maximal inhibitory concentration: 3970 nM
For compound 3 the middle estimate is 1.5-fold (0.18 log units) above the measured one; low and high end bracket the measured number.
By their numbers in this assay, from the lowest: compounds 1 and 3 (each within the scatter of the next); then compound 2.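

In this assay, methyl in place of trifluoromethyl on the oxygen gives a 5.6-fold lower number from compound 2 to compound 3 (0.75 log units; beyond the scatter), so the weak number of compound 2 goes with the trifluoromethoxy group as a whole and not with the mere presence of an oxygen at this place. The second comparison, methoxy in place of fluoro on the same aromatic carbon, reads a 1.7-fold higher number from compound 1 to compound 3 (0.22 log units; within the scatter), which means that these two groups cannot be told apart in this assay, and among the three groups shown only trifluoromethoxy stands apart from the others. Nothing available here explains why the groups fall as they do.

The compounds shown leave open how a hydroxy group, a chloro, an ethoxy chain or a bare hydrogen on that carbon would read in this assay, and so whether trifluoromethoxy is a lone exception or one end of a wider series. They also leave open how far the numbers would move with a change elsewhere in the shared core, such as an amine in place of the methoxy group carried by the core or a longer chain in place of the ethyl on the sulfonyl group.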